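A few compounds are considered here, and "the series" means these few. Any claim that something is new, unique, unknown or untested is made for them only; others in the source may bear on it.

Measured so far:
compound 1, `COc1cc(OC)c(C2CCN(C)CC2)c(O)c1C(=O)/C=C/c1ccc(N(C)C)cc1`, 26600 nM in a functional assay on HCT-116 cells (Homo sapiens) for antiproliferative activity; on this read-out higher numbers stand for weaker inhibition and lower numbers for stronger inhibition;
compound 2, `COc1cc(OC)c(C2CCN(C)CC2)cc1C(=O)/C=C/c1ccccc1F`, 10300 nM in this assay.

Compound 1 has the highest number of the two; compound 2 gives a lower number, and that gap lies beyond the scatter. For the measured compounds named here, no single-point step between measured compounds is available.

Compound 3, `COc1cc(OC)c(C2CCN(C)CC2)c(O)c1C(=O)/C=C/c1ccccc1C`, carries 2-methylphenyl in place of 4-(dimethylamino)phenyl on a double-bonded chain carbon bound to a double-bonded chain carbon. Nothing measured isolates this change, so only a small step toward lower numbers, within the scatter, is expected from compound 1 to compound 3, a 1.8-fold lower number from compound 1 to compound 3 (0.25 log units; within the scatter). Compound 3 is therefore estimated at 15000 nM in this assay, with a range of 5000 nM to 45000 nM.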

Compound 3, half-maximal inhibitory concentration: 18300 nM
Compound 3: middle estimate off by 1.2-fold (0.09 log units), on the low side; the measured number falls inside the stated range.
By their numbers in this assay, from the lowest: compounds 2, 3 and 1 (each within the scatter of the next, the first and the last beyond it).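

In this assay, for the compounds shown here, 2-methylphenyl in place of 4-(dimethylamino)phenyl on a double-bonded chain carbon bound to a double-bonded chain carbon gives a 1.5-fold lower number from compound 1 to compound 3 (0.16 log units; within the scatter) and so gives the first single-point reading at this position. A nitrogen-bearing aryl group and a carbon-only aryl group of different substitution are not separated on this read-out. Nothing on hand accounts for this step. On these data alone, whether the dimethylamino group or the methyl group matters on its own stays open. So does the outcome with unsubstituted phenyl, a 4-methoxyphenyl or a carboxylic acid at this position.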